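From 4-hydroxyphenyl to 3-chloro-4-hydroxyphenyl in compound 4

The compounds below may be only part of what the source reports. "The series", "measured", "known", "first", "only" and "open" are said of these compounds alone.

Of the compounds shown here, three on a shared core have been measured in a functional assay on MCF7 cells (Homo sapiens) for antiproliferative activity; on this read-out higher numbers stand for weaker inhibition and lower numbers for stronger inhibition. Compound 1 (`CC(=O)Oc1ccc(C(=O)Nc2cc3ccc(OC4CCN(C)CC4)c(C)c3oc2=O)cc1`) gives 1620 nM, compound 2 (`Cc1c(OC2CCN(C)CC2)ccc2cc(NC(=O)c3ccccc3)c(=O)oc12`) gives 11700 nM and compound 3 (`Cc1c(OC2CCN(C)CC2)ccc2cc(NC(=O)c3ccc(O)cc3)c(=O)oc12`) gives 1430 nM. The gap a 1.1-fold lower number from compound 1 to compound 3 (0.05 log units; within the scatter) stays within the scatter, so compound 3 stands level with compound 1, and only compound 2 sits apart from the other two.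

Compound 4 (`Cc1c(OC2CCN(C)CC2)ccc2cc(NC(=O)c3ccc(O)c(Cl)c3)c(=O)oc12`) differs from compound 3 in one place: chloro in place of hydrogen on an aromatic carbon. This is chloro in place of hydrogen on an aromatic carbon, ortho to a hydroxy group. Within the data shown here, no measured compound carries chloro, so no step speaks to this change directly. The closest evidence is two single changes on the same aromatic group: an 8.2-fold lower number from compound 2 to compound 3 (0.91 log units; beyond the scatter) for hydroxy in place of hydrogen, and a 7.2-fold higher number from compound 1 to compound 2 (0.86 log units; beyond the scatter) for hydrogen in place of acetoxy. Both are modest and beyond the scatter, and they give the only measure of how far one substituent has moved the number here. The direction for chloro cannot be read from these data, so a small change is expected, with no clear step beyond the scatter. The expected step is a 1.2-fold lower number from compound 3 to compound 4 (0.08 log units; within the scatter). For compound 4 the estimated value is 1200 nM, with an expected range of 400 nM to 3600 nM.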

Compound 4, half-maximal inhibitory concentration: 1480 nM
The estimate for compound 4 lay 1.2-fold (0.09 log units) below the measured number; measured number inside the range.
By their numbers in this assay, from the lowest: compounds 3, 4 and 1 (each within the scatter of the next); then compound 2.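

In this assay, chloro in place of hydrogen on the aromatic carbon ortho to the hydroxy group gives a 1.0-fold higher number from compound 3 to compound 4 (0.01 log units; within the scatter), so this position accepts chloro with no change in the read-out beyond the scatter. The distance from the unsubstituted phenyl amide persists with the new group, at a 7.9-fold lower number from compound 2 to compound 4 (0.90 log units; beyond the scatter), while the 3-chloro-4-hydroxyphenyl and 4-acetoxyphenyl compounds remain level, at a 1.1-fold lower number from compound 1 to compound 4 (0.04 log units; within the scatter); among the compounds shown, only compound 2 still stands apart. No supporting measurement accounts for the flat chloro step.

The compounds shown leave open whether this position stays as flat with a larger or differently built group, such as methoxy, a dimethylamino group or a carboxylic acid. They also leave open what chloro does without the neighbouring hydroxy group, since a 3-chlorophenyl amide on the shared core would separate the contribution of chloro from that of the hydroxy group.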